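A few compounds are considered here, and "the series" means these few. Any claim that something is new, unique, unknown or untested is made for them only; others in the source may bear on it.

Going by the values given here, in an in vivo functional assay on the whole organism for inhibition, with Rattus norvegicus as the target (a higher number here means that more compound is needed for the effect, a lower number that less compound is needed), compound 2 (`CCCCc1nc(C)c(CCC(=O)N2CCOCC2)c(=O)n1Cc1ccc(-c2ccccc2-c2nnn[nH]2)cc1`) gives 0.143 mg/kg, the higher of the two numbers so far, and compound 1 (`CCCCc1nc(C)c(CC(=O)N2CCC[C@H]2C(N)=O)c(=O)n1Cc1ccc(-c2ccccc2-c2nnn[nH]2)cc1`) gives 0.023 mg/kg. Compound 3 (`CCCCc1nc(C)c(CC(=S)N2CCCCCC2)c(=O)n1Cc1ccc(-c2ccccc2-c2nnn[nH]2)cc1`) carries a group of 9 heavy atoms (7 carbon, 1 nitrogen, 1 sulfur; one seven-membered non-aromatic ring with 1 hetero atom) in place of a group of 9 heavy atoms (6 carbon, 1 nitrogen, 2 oxygen; one six-membered non-aromatic ring with 2 hetero atoms), on a saturated chain carbon bound to an aromatic carbon. Among the compounds with values here, the one measured step that bears on this change is a 6.2-fold higher number from compound 1 to compound 2 (0.79 log units; beyond the scatter), a modest step on the same saturated chain carbon bound to an aromatic carbon. Within the data shown here, no measured compound carries the entering group, so a smaller step towards a lower number in this assay is expected, on thin evidence. For compound 3 the estimated value is 0.06 mg/kg, with an expected range of 0.015 mg/kg to 0.25 mg/kg, which means an expected 2.4-fold lower number from compound 2 to compound 3 (0.38 log units; beyond the scatter).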

Compound 3, dose for half-maximal effect: 0.034 mg/kg
The estimate for compound 3 lay 1.8-fold (0.25 log units) above the measured number, and the stated range covers the measured number.
By their numbers in this assay, from the lowest: compounds 1 and 3 (each within the scatter of the next); then compound 2.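

In this assay, putting the sulfur-bearing group with its seven-membered non-aromatic ring in place of ((morpholin-4-yl)carbonyl)methyl on the saturated chain carbon gives a 4.2-fold lower number from compound 2 to compound 3 (0.62 log units; beyond the scatter). The other comparison, a 1.5-fold higher number from compound 1 to compound 3 (0.17 log units; within the scatter), shows that two quite different groups at this place give values within the scatter of each other, so a low number here does not require the carbamoyl group of compound 1. No measurement available explains either step.

As far as these compounds go, compound 3 differs from compound 2 in its ring, its sulfur and its chain together, so their separate contributions remain open. The same seven-membered ring carrying a carbonyl oxygen in place of the sulfur would begin to separate them.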